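From 3-hydroxyphenyl to 2-fluorophenyl on the piperazine

The compounds below may be only part of what the source reports. "The series", "measured", "known", "first", "only" and "open" are said of these compounds alone.

Of the compounds shown here, two sharing one core have been measured in an assay for displacement of a labelled ligand from Adrenergic receptor alpha-1 (Homo sapiens); a higher number here means a weaker inhibitor, a lower number a stronger inhibitor. Compound 1 `Cn1c(=O)cnn(CCCCN2CCN(c3ccccc3OCCCF)CC2)c1=O` gives 280 nM. Compound 2 `Cn1c(=O)cnn(CCCCN2CCN(c3cccc(O)c3)CC2)c1=O` reaches only the limit of the assay and gives > 10000 nM. That limit is where one of the two values sits (the limit of > 10000 nM in this assay, at which 1 of the 2 values shown sits), so compound 2 stands at the weak end of what has been seen, with no number of its own.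

Compound 3 `Cn1c(=O)cnn(CCCCN2CCN(c3ccccc3F)CC2)c1=O` differs from compound 2 in one place: 2-fluorophenyl in place of 3-hydroxyphenyl on an amine nitrogen in a ring. The change removes a hydrogen-bond donor and a hydrogen-bond acceptor and replaces the hydroxyl with a fluorine on the phenyl ring.

For the measured compounds named here, no measured step connects two compounds here, so the size of the step is an expectation only. Compound 3 is expected to be a stronger inhibitor than the limit shown for compound 2, with an expected value of 600 nM, in a range from 100 nM to 5000 nM. The expected step of an at least 16-fold lower number from compound 2 to compound 3 (1.22 log units; beyond the scatter) thus runs toward stronger binding.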

Compound 3, inhibition constant: 9.73 nM
Estimate against measurement, compound 3: 62-fold (1.79 log units) above, outside the stated range (below it).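

Placing 2-fluorophenyl in place of 3-hydroxyphenyl on an amine nitrogen in a ring gives an at least 1000-fold lower number from compound 2 to compound 3 (3.01 log units; beyond the scatter) in this assay, so the group at this position can decide between no measurable number and strong binding on the shared core. That step has only a lower bound, since compound 2 stands at a limit and has no number of its own: the limit of > 10000 nM in this assay, at which 1 of the 3 values shown sits. Fluoro in place of 3-fluoropropoxy on an aromatic carbon gives a 29-fold lower number from compound 1 to compound 3 (1.46 log units; beyond the scatter), so among the compounds shown, the 3-fluoropropoxy chain is not needed for strong binding.

The compounds shown leave open whether the first step comes from losing the hydroxyl, gaining the fluorine or moving the substituent on the phenyl ring. An unsubstituted phenyl, a 3-fluorophenyl or a 2-hydroxyphenyl group would separate these.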